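The source may report more compounds than this note shows. Statements on the series, on what has been measured and on what is new or still open speak of the compounds shown alone.

Compound 1 `COc1ccc(Oc2ccc(N3CC(=O)N([C@@H](CC4CCN(C(=O)C(C)C)CC4)c4nc5ccc(C)cc5n4C)C3=O)cc2)cc1` gives 1580 ng.h/mL in an ADME assay on the whole organism (Rattus norvegicus, strain Sprague-Dawley) for pharmacokinetics, read by LC-MS, with a stated time of 6 h, at a dose of 30 mg/kg by the oral route; a higher number here means more compound in the circulation at the dose given, a lower number less compound in the circulation.
Compound 2 `CC(C)C(=O)N1CCC(C[C@@H](c2nc3ccc(F)cc3n2C2CC2)N2C(=O)CN(c3ccc(Oc4ccc(F)cc4)cc3)C2=O)CC1` gives 15600 ng.h/mL.

Of these two, compound 2 stands higher, and its gap to compound 1 lies beyond the usual scatter. Compound 3 `Cc1ccc2nc([C@H](CC3CCN(C(=O)C(C)C)CC3)N3C(=O)CN(c4ccc(Oc5ccc(F)cc5)cc4)C3=O)n(C3CC3)c2c1` differs from compound 2 in one place: methyl in place of fluoro on an aromatic carbon. Among the compounds with values here, no measured pair shows this change on its own, so its effect is unknown. Compound 1 also carries a methyl on its fused ring system but differs from compound 2 elsewhere as well, so it cannot settle the question. A small downward step, expected at a 1.7-fold lower number from compound 2 to compound 3 (0.24 log units; within the scatter) and likely within the scatter, is assumed. Compound 3 is therefore expected to give about 9000 ng.h/mL, with a range from 3000 ng.h/mL to 25000 ng.h/mL.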

Compound 3, area under the concentration-time curve: 3960 ng.h/mL
Beside the measured number, compound 3's estimate is 2.3-fold (0.36 log units) above it, within the range that was stated.
By their numbers in this assay, from the lowest: compound 1; then compound 3; then compound 2.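

Swapping fluoro for methyl on this aromatic carbon, part of a fused system of two rings, is the first single change that can be read in this assay, and it gives a 3.9-fold lower number from compound 2 to compound 3 (0.60 log units; beyond the scatter). One heavy atom exchanged for another at this place is thus enough to leave less compound in the circulation, with no ring, hydrogen-bond donor or acceptor, or net charge added. No measurement shown here bears on the reason for this drop.

On these data alone, it remains open whether the same swap would have a similar effect with the other groups of compound 1 in place. As far as these compounds go, how chloro, methoxy or an amine on this carbon would compare also remains open.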